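Swapping an Aryl Amide for a Methoxyacetamide

The source may hold more compounds than are shown below. What is called first, only, known or untested is meant among the compounds shown, and "the series" means these compounds.

Compound 1 `O=C(Nc1nccs1)c1cccc(Nc2ncc(F)c(Nc3ccc(F)cc3)n2)c1`: in a functional assay on A549 cells (Homo sapiens) for antiproliferative activity, read by sulforhodamine B assay, with a stated time of 3 days (on this read-out lower numbers stand for stronger inhibition of growth and higher numbers for weaker inhibition of growth), compound 1 gives > 10000 nM, which is a limit of the assay and not a number.
Compound 2 `COc1ccc(NC(=O)c2cccc(Nc3ncc(F)c(Nc4ccc(F)cc4)n3)c2)cc1`: in this assay compound 2 gives 11000 nM.
Compound 3 `CN(C)c1ccc(C(=O)Nc2cccc(Nc3ncc(F)c(Nc4ccc(F)cc4)n3)c2)cc1`: in this assay compound 3 gives > 10000 nM, which again is a limit of the assay.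

Going by the values given here, compound 2 thus stands as the only compound of the three with a measured number, and that number sits close to the limit at which the other two rest. The step that the limit leaves unreadable from compound 1 to compound 2 cannot be read, since the value of compound 1 is a limit; the limit of > 10000 nM in this assay, at which 2 of the 3 values shown sit, marks where two of the three values lie.

Compound 4 `COCC(=O)Nc1cccc(Nc2ncc(F)c(Nc3ccc(F)cc3)n2)c1` differs from compound 2 in one place: ((methoxymethyl)carbonyl)amino in place of (4-methoxyphenyl)carbamoyl on an aromatic carbon. Among the compounds with values here, no measured step bears directly on this change, and no measured compound in this set reaches a clearly readable inhibition. The expectation for compound 4 is therefore a step of no change at the digits printed from compound 2 to compound 4 (within the scatter) of no size beyond the scatter. Compound 4 is estimated at 11000 nM, within 3000 nM to 40000 nM.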

Compound 4, concentration for 50% growth inhibition: 2050 nM
Estimate against measurement, compound 4: 5.4-fold (0.73 log units) above; the measured number lies below the stated range.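

In this assay, a smaller group with no ring on this aromatic carbon gives the clearest growth inhibition so far, with a 5.4-fold lower number from compound 2 to compound 4 (0.73 log units; beyond the scatter). The direction holds when the amide stays the same way round and only the group on its carbonyl changes, methoxymethyl replacing 4-(dimethylamino)phenyl, with an at least 4.8-fold lower number from compound 3 to compound 4 (0.68 log units; beyond the scatter), and also against the thiazole-bearing amide, with an at least 4.8-fold lower number from compound 1 to compound 4 (0.68 log units; beyond the scatter). These last two steps start from values that are limits of the assay and not numbers: the limit of > 10000 nM in this assay, at which 2 of the 4 values shown sit.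

The compounds shown cannot tell whether the gain follows from losing the aromatic ring, from the methoxy oxygen, or from which way round the amide sits. A plain acetamide, a longer methoxy-ending chain or a chain ending in an amine at this place would begin to separate these.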